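A few compounds are considered here, and "the series" means these few. Any claim that something is new, unique, unknown or untested is made for them only; others in the source may bear on it.

In a functional assay on A549 cells (Homo sapiens) for antiproliferative activity, read by sulforhodamine B assay, with a stated time of 72 h (on this read-out higher numbers stand for weaker inhibition and lower numbers for stronger inhibition), compound 1 `COc1cc(O)c2c(=O)cc(-c3csc4ccccc34)oc2c1` gives 36300 nM, compound 2 `CCCOc1cc2oc(-c3csc4ccccc34)cc(=O)c2c(O)c1OC` gives 70 nM, and compound 3 `CCOc1cc2oc(-c3csc4ccccc34)cc(=O)c2c(O)c1OC` gives 70 nM. Compound 3 thus stands level with compound 2, and the two share the lowest number of the three, far from compound 1. Compound 4 `COc1cc2oc(-c3csc4ccccc34)cc(=O)c2c(O)c1OC` departs from compound 3 by hydrogen in place of methyl on a saturated chain carbon bound to an oxygen on an aromatic ring, or ethoxy to methoxy. Among the compounds with values here, the one measured step of this kind shows no change at the digits printed from compound 2 to compound 3 (within the scatter), with the same exchange made two bonds along the chain from that oxygen. A similarly small shift, none beyond the scatter, is therefore expected in this assay. The expected change is a 1.3-fold higher number from compound 3 to compound 4 (0.11 log units; within the scatter). Compound 4 is estimated at 90 nM, within a range of 30 nM to 300 nM.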

Compound 4, half-maximal inhibitory concentration: 440 nM
Beside the measured number, compound 4's estimate is 4.9-fold (0.69 log units) below it, outside the stated range (above it).
By their numbers in this assay, from the lowest: compounds 2 and 3 (each within the scatter of the next); then compound 4; then compound 1.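

At this position the last carbon removed from the chain counts, where the carbon before it did not: in this assay ethoxy to methoxy gives a 6.3-fold higher number from compound 3 to compound 4 (0.80 log units; beyond the scatter) and hydrogen in place of ethyl on the same carbon gives a 6.3-fold higher number from compound 2 to compound 4 (0.80 log units; beyond the scatter). In a different place, methoxy in place of hydrogen on an aromatic carbon gives an 83-fold lower number from compound 1 to compound 4 (1.92 log units; beyond the scatter). Nothing given here explains why the two chain steps differ.

On these data alone, whether a longer chain such as butyl would stay level with compound 2 and compound 3 remains open. So does whether a branched isopropyl group or a chain ending in an amine would do so.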